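This account rests on a few compounds, and the source may have more. Where it says the series, first, only, none or still open, it means among the compounds named here.

Measured so far:
compound 1, `CC1=CC[C@H](C(C)(C)NC(=S)N/N=C/c2ccccc2)CC1`, gives 8700 nM in a functional assay on OVCAR-3 cells (Homo sapiens) for inhibition, read by sulforhodamine B assay, with a stated time of 48 h; on this read-out higher numbers stand for weaker inhibition of growth and lower numbers for stronger inhibition of growth.
compound 3, `CC1=CC[C@H](C(C)(C)NC(=S)N/N=C/c2cccc(Cl)c2)CC1`, gives 13600 nM in this assay.
compound 2, `CC1=CC[C@H](C(C)(C)NC(=S)N/N=C/c2ccc(O)cc2)CC1`, sits at the limit of > 100000 nM in this assay, at which 1 of the 3 values shown sits; in this assay compound 2 gives > 100000 nM, which is a limit of the assay and not a number.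

Of the two numbers, compound 3 holds the higher one, but its gap to compound 1, a 1.6-fold higher number from compound 1 to compound 3 (0.19 log units; within the scatter), is too small to tell the two apart. The other changes on the same ring behaved very differently: an at least 11-fold higher number from compound 1 to compound 2 (1.06 log units; beyond the scatter) was a large loss, and an at least 7.3-fold lower number from compound 2 to compound 3 (0.86 log units; beyond the scatter) recovered at least much of it.

Compound 4, `CC1=CC[C@H](C(C)(C)NC(=S)N/N=C/c2ccco2)CC1`, differs from compound 3 in one place: furan-2-yl in place of 3-chlorophenyl on a carbon with a double bond to nitrogen. Going by the values given here, no measured step swaps the ring itself, so the expectation rests on how the ring tolerated the chloro and hydroxy changes, which ranged from no clear shift to a large loss. Since the chloro step stayed inside the scatter and the hydroxy step did not, a step of a 1.1-fold higher number from compound 3 to compound 4 (0.04 log units; within the scatter) is expected, most likely small. For compound 4 in this assay the estimate is 15000 nM, with a range from 4000 nM to 60000 nM.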

Compound 4, concentration for 50% growth inhibition: 10800 nM
Beside the measured number, compound 4's estimate is 1.4-fold (0.14 log units) above it; low and high end bracket the measured number.
By their numbers in this assay, from the lowest: compounds 1, 4 and 3 (each within the scatter of the next). At a limit, above all of these: compound 2.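

Swapping the six-membered ring of carbon for the smaller furan-2-yl leaves the result in this assay unresolved, since a 1.3-fold lower number from compound 3 to compound 4 (0.10 log units; within the scatter) and a 1.2-fold higher number from compound 1 to compound 4 (0.09 log units; within the scatter) both lie within the scatter, so this place on a carbon with a double bond to nitrogen accepts a five-membered aromatic ring with 1 hetero atom as readily as phenyl or 3-chlorophenyl. Placing furan-2-yl where compound 2 carries 4-hydroxyphenyl gives an at least 9.2-fold lower number from compound 2 to compound 4 (0.96 log units; beyond the scatter), which shows that an oxygen in the ring does not bring the large loss seen with the hydroxy group, and compound 2 is the only one of the four that goes against this tolerance of ring changes. The value of compound 2 is a limit of the assay and not a number: the limit of > 100000 nM in this assay, at which 1 of the 4 values shown sits.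

The three rings with measured numbers cannot be told apart, so the compounds shown leave open whether any group at this place can strengthen inhibition of growth beyond the scatter. They also leave open whether the loss is specific to hydroxy or would return with an amine, a methoxy group or a carboxylic acid on the phenyl ring.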